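Adding one methoxy to compound 1

This account rests on a few compounds, and the source may have more. Where it says the series, first, only, none or still open, it means among the compounds named here.

Compound 1 `COc1cccc(/C=C2\CCC/C(=C\c3cccc(OC)c3OC)C2=O)c1`: 9900 nM
Compound 2 `COc1cccc(/C=C2\CCC/C(=C\c3cccc(Cl)c3Cl)C2=O)c1OC`: 19300 nM
Compound 3 `COc1cc(/C=C2\CCC/C(=C\c3cccc(OC)c3OC)C2=O)cc(OC)c1`: not yet measured

Going by the values given here, only two compounds have numbers in a functional assay on HT-1080 cells (Homo sapiens) for cytotoxicity, read by MTT assay, with a stated time of 72 h; a lower number here means a stronger inhibitor, a higher number a weaker inhibitor. Among the compounds with values here, the one measured step, a 1.9-fold higher number from compound 1 to compound 2 (0.29 log units; within the scatter), stays within the scatter, so compound 1 stands level with the only other measured compound. Compound 3 differs from compound 1 by methoxy in place of hydrogen on an aromatic carbon, meta to a large group and meta to a methoxy group. The measured step replaced the whole 3-methoxyphenyl group, the group that takes the new methoxy, and the number stayed within the scatter. A smaller edit at that group is therefore not expected to move the number beyond the scatter in this assay, though a single step is thin evidence. The estimated change is a 1.1-fold lower number from compound 1 to compound 3 (0.04 log units; within the scatter). For compound 3 the expected value is 9000 nM, with an estimated range from 3500 nM to 22000 nM.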

Compound 3, half-maximal inhibitory concentration: 4500 nM
Compound 3: middle estimate off by 2.0-fold (0.30 log units), on the high side; low and high end bracket the measured number.
By their numbers in this assay, from the lowest: compound 3; then compounds 1 and 2 (each within the scatter of the next).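

In this assay, going by these compounds alone, a 2.2-fold lower number from compound 1 to compound 3 (0.34 log units; beyond the scatter) is the first step in this set to lie beyond the scatter, though it is modest. It shows that this aromatic carbon, meta to a large group and meta to a methoxy group, can register a single methoxy in place of hydrogen, whereas a 1.9-fold higher number from compound 1 to compound 2 (0.29 log units; within the scatter) put 2,3-dichlorophenyl in place of the whole 3-methoxyphenyl group and stayed within the scatter. Nothing given here accounts for this step.

A single step cannot tell whether methoxy itself matters or whether other groups at this carbon would serve equally well. The compounds shown leave open how a hydroxyl, a fluorine or an amine there would read in this assay, and whether a longer ether chain would keep the lower number.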